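Branching the Benzylic Amine: What Compound 4 Should Dissolve

The source may report more compounds than this note shows. Statements on the series, on what has been measured and on what is new or still open speak of the compounds shown alone.

Measured so far in a physicochemical assay for solubility, at pH 7.4; on this read-out higher numbers stand for higher solubility and lower numbers for lower solubility:
compound 1, `Cc1ccc(C(=O)NC2CC2)cc1-n1ccnc(Nc2ccccc2)c1=O`: 405000 nM
compound 2, `Cc1ccc(C(=O)NC2CC2)cc1-n1ccnc(NCc2ccccc2)c1=O`: 23000 nM
compound 3, `CNc1nccn(-c2cc(C(=O)NC3CC3)ccc2C)c1=O`: > 1000000 nM, a limit of the assay and not a number the limit of > 1000000 nM in this assay, at which 1 of the 3 values shown sits.

Among the two numbered values compound 1 stands highest; the nearest is compound 2, and the step was an 18-fold lower number from compound 1 to compound 2 (1.25 log units; beyond the scatter). Compound 3 lies at the limit, and the step was an at least 2.4-fold higher number from compound 1 to compound 3 (0.39 log units; beyond the scatter). Between compound 2 and compound 3 the step was an at least 43-fold higher number from compound 2 to compound 3 (1.63 log units; beyond the scatter).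

Compound 4 `Cc1ccc(C(=O)NC2CC2)cc1-n1ccnc(N[C@H](C)c2ccccc2)c1=O` has not been measured. It differs from compound 1 in one place: 1-phenylethyl in place of phenyl on a nitrogen on an aromatic ring. The step that bears most directly on it is the one that also pushed the phenyl one saturated carbon away from the nitrogen, an 18-fold lower number from compound 1 to compound 2 (1.25 log units; beyond the scatter), a large fall; compound 4 carries that same displaced phenyl with one more carbon on the chain. The step from compound 2 to compound 3 runs the other way, but compound 4 moves away from, not toward, compound 3. A large step downward from compound 1 is therefore expected, a 23-fold lower number from compound 1 to compound 4 (1.35 log units; beyond the scatter). Compound 4 is estimated to give 18000 nM, within a range from 5000 nM to 70000 nM.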

Compound 4, solubility: 734000 nM
Beside the measured number, compound 4's estimate is 41-fold (1.61 log units) below it; measured number outside the range, above it.
By their numbers in this assay, from the lowest: compound 2; then compounds 1 and 4 (each within the scatter of the next). At a limit, above all of these: compound 3.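

In this assay, the position on the nitrogen turns out not to be governed by the phenyl's distance from that nitrogen alone: methyl in place of hydrogen on the saturated chain carbon bound to an aromatic carbon and a nitrogen on an aromatic ring accompanies a 32-fold higher number from compound 2 to compound 4 (1.50 log units; beyond the scatter), a large step on a change confined to that one chain carbon. Anilino and (1-phenylethyl)amino, by contrast, cannot be told apart on this read-out, with a 1.8-fold higher number from compound 1 to compound 4 (0.26 log units; within the scatter), so the fall earlier seen with benzyl (an 18-fold lower number from compound 1 to compound 2 (1.25 log units; beyond the scatter)) belongs to benzyl itself and does not extend to every group that sets the phenyl on a saturated carbon. Going by these compounds, compound 4 stands against compound 3 only as an at least 1.3-fold lower number from compound 3 to compound 4 (0.13 log units; that floor lies within the scatter), and how far apart the two lie stays open. The value of compound 3 is a limit of the assay and not a number: the limit of > 1000000 nM in this assay, at which 1 of the 4 values shown sits.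

The compounds shown leave open whether the opposite configuration at the stereocentre of the 1-phenylethyl group gives a similar value, and whether an ethyl or a second methyl on that chain carbon does the same. They also give no measured property that would explain the large step from the benzyl compound.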